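Amide-nitrogen substituent variation in a shared-core series

This account rests on a few compounds, and the source may have more. Where it says the series, first, only, none or still open, it means among the compounds named here.

Measured compounds in a functional assay on HEK293 cells for agonist activity at D(4) dopamine receptor (Homo sapiens), read by FLIPR; a lower number here means a smaller maximal response, a higher number a larger maximal response:
compound 1, `O=C(CN1CCC(c2cccc[n+]2[O-])CC1)NC1CCCCC1`: 58%
compound 2, `CC(C)Oc1cccc(NC(=O)CN2CCC(c3cccc[n+]3[O-])CC2)c1`: 48%
compound 3, `Cc1cc(Br)ccc1NC(=O)CN1CCC(c2cccc[n+]2[O-])CC1`: 61%

Compound 3 and compound 1 lie within the scatter of each other; compound 2 gives a number below compound 3 by more than the scatter. Among the measured compounds shown here, only one step between single-change neighbours is available: a number 3 percentage points higher from compound 1 to compound 3 (within the scatter), a change that swaps a saturated ring for an aromatic one on the amide-type nitrogen without moving the response beyond the scatter.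

Compound 4, `CSc1cccc(NC(=O)CN2CCC(c3cccc[n+]3[O-])CC2)c1`, differs from compound 3 as follows: 3-(methylsulfanyl)phenyl in place of 4-bromo-2-methylphenyl on an amide-type nitrogen. For the measured compounds named here, both groups are aromatic and of the same heavy-atom count, so the one measured step suggests little movement; compound 2, which also carries a 3-substituted phenyl on the amide-type nitrogen, sits lower and argues for a modest downward tendency. The expected step of a number 9 percentage points lower from compound 3 to compound 4 (within the scatter) is therefore small. Compound 4 is estimated at 52%, within 38% to 66%.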

Compound 4, largest response reached (reported as efficacy), in percent of the reference or control that the assay uses: 56%
Estimate against measurement, compound 4: 4 percentage points below, and the stated range covers the measured number.
By their numbers in this assay, from the lowest: compounds 2, 4, 1 and 3 (each within the scatter of the next, the first and the last beyond it).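

Notes on the amide-type nitrogen in this assay: 3-(methylsulfanyl)phenyl in place of 4-bromo-2-methylphenyl gives a number 5 percentage points lower from compound 3 to compound 4 (within the scatter), and 3-(methylsulfanyl)phenyl in place of cyclohexyl gives a number 2 percentage points lower from compound 1 to compound 4 (within the scatter), so neither this aromatic exchange nor a second saturated-to-aromatic exchange moves the response beyond the scatter. The series also gains its first change on the aromatic carbon itself, where methylsulfanyl in place of isopropoxy gives a number 8 percentage points higher from compound 2 to compound 4 (within the scatter), again without a separation beyond the scatter. No measurement in hand accounts for any of these steps.

Still open, on these data alone, is how the response would read with an amine or a carboxylic acid in place of methylsulfanyl on the aromatic carbon. Also open, as far as these compounds go, is whether a longer chain on the amide-type nitrogen would separate from compound 4 beyond the scatter.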